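Thienyl nucleoside series: expectation for the dimethylamino analogue

This account rests on a few compounds, and the source may have more. Where it says the series, first, only, none or still open, it means among the compounds named here.

Measured so far:
compound 1 `Cc1ncnc2c1c(-c1cccs1)cn2[C@@H]1O[C@H](CO)[C@@H](O)[C@H]1O`; in a functional assay on CCRF-CEM cells (Homo sapiens), read by MTT assay, with a stated time of 72 h (on this read-out higher numbers stand for weaker inhibition and lower numbers for stronger inhibition), compound 1 gives > 20000 nM, which is a limit of the assay.
compound 2 `CNc1ncnc2c1c(-c1cccs1)cn2[C@@H]1O[C@H](CO)[C@@H](O)[C@H]1O`; in this assay compound 2 gives > 20000 nM, again a limit of the assay.

Compound 2 stands at the assay limit, as does compound 1, so both values shown sit there (the limit of > 20000 nM in this assay, at which 2 of the 2 values shown sit), and the step that the two limits leave unreadable from compound 1 to compound 2 cannot be read. Compound 3 `CN(C)c1ncnc2c1c(-c1cccs1)cn2[C@@H]1O[C@H](CO)[C@@H](O)[C@H]1O` differs from compound 2 by methyl in place of hydrogen on a nitrogen on an aromatic ring. Going by the values given here, no measured step bears on this change with a readable size; the only step available is the unreadable one just named. Compound 3 is therefore expected to stay at the limit as well, with an estimated step that the limit leaves unreadable from compound 2 to compound 3 and an estimated value of 30000 nM, ranging from 10000 nM to 100000 nM.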

Compound 3, half-maximal inhibitory concentration: > 20000 nM
Compound 3: only a limit was reported; the forecaster's own chance of this, stated with the estimate: 85%; the middle value is on the limit's open side.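

Compound 3 sits with compound 1 and compound 2 at a limit of the assay, so no step among these compounds can be read: the limit of > 20000 nM in this assay, at which 3 of the 3 values shown sit.

The compounds shown leave open whether any of these groups on the shared core gives a measurable value in this assay.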